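This account rests on a few compounds, and the source may have more. Where it says the series, first, only, none or still open, it means among the compounds named here.

Among the compounds with values here, compound 2 `O=S(=O)(NCCNc1nccc(-c2c(-c3cccc(F)c3)nc3sccn23)n1)c1ccc(Br)cc1` is one of two compounds measured so far in a functional assay on A-375 cells (Homo sapiens) for cytotoxicity, read by MTT assay; on this read-out lower numbers stand for stronger inhibition and higher numbers for weaker inhibition. Within the data shown here, compound 2 gives 13500 nM, and compound 1 `O=S(=O)(NCCCNc1nccc(-c2c(-c3cccc(F)c3)nc3sccn23)n1)c1ccc(F)cc1` gives 14500 nM; the single step in hand, a 1.1-fold lower number from compound 1 to compound 2 (0.03 log units; within the scatter), separates them. Compound 3 `O=C(NCCNc1nccc(-c2c(-c3cccc(F)c3)nc3sccn23)n1)c1ccc(C(F)(F)F)cc1` is not yet measured. It differs from compound 2 in one place: (4-(trifluoromethyl)phenyl)carbonyl in place of (4-bromophenyl)sulfonyl on an amine nitrogen. That measured step changed the chain and the ring substituent, not the sulfonyl group, and offers no guide here. Compound 3 is therefore expected to show no step beyond the scatter, a 1.1-fold higher number from compound 2 to compound 3 (0.05 log units; within the scatter). Compound 3 is estimated at 15000 nM, within a range from 5000 nM to 45000 nM.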

Compound 3, half-maximal inhibitory concentration: 8710 nM
Compound 3: middle estimate off by 1.7-fold (0.24 log units), on the high side; measured number inside the range.
By their numbers in this assay, from the lowest: compounds 3, 2 and 1 (each within the scatter of the next).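

In this assay the amine nitrogen on the saturated chain takes (4-(trifluoromethyl)phenyl)carbonyl in place of (4-bromophenyl)sulfonyl with a 1.5-fold lower number from compound 2 to compound 3 (0.19 log units; within the scatter) as the only shift, so at this place a carbonyl link serves as well as a sulfonyl link as far as this read-out can tell. The link and the ring substituent both differ in this single step, so their shares cannot be separated. No supporting measurement bears on this result.

Still open, as far as these compounds go, is whether a longer chain alters the picture with the carbonyl link, and how a simple acetyl group or a carboxylic acid on the ring would read at this nitrogen.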